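Ring Closure at the Alkyne Tip of a Kinase Inhibitor

A few compounds are considered here, and "the series" means these few. Any claim that something is new, unique, unknown or untested is made for them only; others in the source may bear on it.

Measured so far:
compound 1 `CC(C)(O)C#Cc1ccc2nccc(-c3cn[nH]c3)c2c1` – 1720 nM
compound 2 `CC(O)(C#Cc1ccc2nccc(-c3cn[nH]c3)c2c1)c1ccccn1` – 591 nM

Of the compounds shown here, two sharing one core have been tested in an assay for inhibition of mitogen-activated protein kinase kinase kinase 14 (Homo sapiens), read by luminescence and ADP-Glo, with a stated time of 120 min, in the presence of a further agent that is not named here; a higher number here means a weaker inhibitor, a lower number a stronger inhibitor. Compound 1 gives 1720 nM and stands as the higher of the two numbers; the nearest is compound 2, reached by a 2.9-fold lower number from compound 1 to compound 2 (0.46 log units; beyond the scatter). Compound 3 `OC1(C#Cc2ccc3nccc(-c4cn[nH]c4)c3c2)CCCCC1` has not been measured. It differs from compound 1 by 1-hydroxycyclohexyl in place of 1-hydroxy-1-methylethyl on a triple-bonded carbon. Among the measured compounds shown here, the only step recorded so far, a 2.9-fold lower number from compound 1 to compound 2 (0.46 log units; beyond the scatter), concerns a different exchange at the same position, an aromatic group in place of a methyl, so it bears only loosely on the present change, which closes the two methyl carbons into a saturated ring. A change of moderate size is therefore expected in this assay, likely toward a somewhat lower number but possibly none beyond the scatter. Compound 3 is estimated at 1000 nM, between 400 nM and 2600 nM, which is an expected step of a 1.7-fold lower number from compound 1 to compound 3 (0.24 log units; within the scatter).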

Compound 3, half-maximal inhibitory concentration: 6050 nM
For compound 3 the middle estimate is 6.1-fold (0.78 log units) below the measured one; measured number above the stated range.
By their numbers in this assay, from the lowest: compound 2; then compound 1; then compound 3.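

Closing the two methyl carbons into 1-hydroxycyclohexyl gives a 3.5-fold higher number from compound 1 to compound 3 (0.55 log units; beyond the scatter) in this assay, so changes on this triple-bonded carbon can raise the number as well as lower it. Read beside a 2.9-fold lower number from compound 1 to compound 2 (0.46 log units; beyond the scatter), this shows that a ring here does not by itself give a lower number: the pyridin-2-yl of compound 2 and the six-membered non-aromatic ring of compound 3 move the number in opposite directions. The data shown offer no measured explanation for this difference between the two groups. From the compounds shown here alone, it remains open whether a smaller saturated ring, such as 1-hydroxycyclopropyl, or a saturated ring containing an amine would give a lower number than compound 3 does. The role of the hydroxyl group is also open, as no compound shown replaces it with a methoxy group or an amine.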